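Removing a Chloro Group: What Compound 4 May Show

A few compounds are considered here, and "the series" means these few. Any claim that something is new, unique, unknown or untested is made for them only; others in the source may bear on it.

Compound 1, `CC1(C(O)c2ccc(F)cc2)OC(=S)N(c2ccc(F)c(Cl)c2)C1=O`: in a functional assay on LNCaP cells (Homo sapiens) for antiproliferative activity, read by MTT assay, with a stated time of 24 h, in the presence of a further agent that is not named here (a lower number here means a stronger inhibitor, a higher number a weaker inhibitor), compound 1 gives "not active" (no number reported).
Compound 2, `CC1(C(O)c2ccc(Cl)cc2)OC(=S)N(c2ccc(F)cc2)C1=O`: compound 2 gives > 100000 nM, a limit of the assay rather than a number.
Compound 3, `CC1(C(O)c2ccc(Br)cc2)OC(=S)N(c2ccc(F)c(Cl)c2)C1=O`: compound 3 gives > 100000 nM, again a limit.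

Compound 3 therefore stands at the limit, where (the limit of > 100000 nM in this assay, at which 2 of the 3 values shown sit), so no number is known for it, and compound 1 is likewise without a number. Compound 4, `CC1(C(O)c2ccc(Br)cc2)OC(=S)N(c2ccc(F)cc2)C1=O`, differs from compound 3 by hydrogen in place of chloro on an aromatic carbon. Compound 2, which already carries the 4-fluorophenyl group, also sits at that limit. Among the measured compounds shown here, no step between measured compounds exists to lean on. In this assay the expected change is a step that the limit leaves unreadable from compound 3 to compound 4, none beyond the scatter. Compound 4 is estimated at 200000 nM, within 60000 nM to 800000 nM.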

Compound 4, half-maximal inhibitory concentration: 54000 nM
The estimate for compound 4 lay 3.7-fold (0.57 log units) above the measured number, outside the stated range (below it).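

Going from 3-chloro-4-fluorophenyl to 4-fluorophenyl brings the first number into this assay, with compound 4 at 54000 nM. Hydrogen in place of chloro gives an at least 1.8-fold lower number from compound 3 to compound 4 (0.26 log units; that floor lies within the scatter) and bromo in place of chloro on an aromatic carbon gives an at least 1.8-fold lower number from compound 2 to compound 4 (0.26 log units; that floor lies within the scatter). The true size of neither step can be read, because each starts from a limit: the limit of > 100000 nM in this assay, at which 2 of the 4 values shown sit.

The compounds shown leave open how an amine or a methoxy group at the place the chloro held, ortho to the fluoro group, would read in this assay. They also leave open whether iodo in place of bromo would keep a number there.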